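Removing a Methyl from a Stilbene Ether: Expected Efficacy

This account rests on a few compounds, and the source may have more. Where it says the series, first, only, none or still open, it means among the compounds named here.

In an assay on HEK293 cells for agonist activity at transient receptor potential cation channel subfamily V member 1 (Homo sapiens), read by calcium flux (on this read-out higher numbers stand for larger maximal responses and lower numbers for smaller maximal responses), compound 1 `COc1cc(/C=C/c2ccccc2)cc(OC)c1` gives < 10%, which is a limit of the assay and not a number. Compound 2 `CC(=O)Oc1ccc(/C=C/c2ccccc2)cc1` likewise gives < 10%, again a limit. Among the measured compounds shown here, compound 3 `COc1cccc(/C=C/c2ccc(O)cc2)c1` also reaches only < 10%, a limit, so it stands at the limit of < 10% in this assay, at which 3 of the 3 values shown sit, together with the other two, and no measured pair differs in a single place. Compound 4 `Oc1ccc(/C=C/c2cccc(O)c2)cc1` has not yet been measured in this assay; it differs from compound 3 by hydrogen in place of methyl on an oxygen on an aromatic ring. With every value shown sitting at the limit, no step beyond the scatter is expected in this assay, in either direction. For compound 4 an efficacy of 8% is estimated, between 0% and 25%. The expected step that the limit leaves unreadable from compound 3 to compound 4 is therefore small.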

Compound 4, largest response reached (reported as efficacy), in percent of the reference or control that the assay uses: < 10%
Compound 4: only a limit was reported; the forecaster's own chance of this, stated with the estimate: 70%; the middle value lies beyond the limit too.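

Compound 3 and compound 4 both stand at a limit of the assay in this assay, so no step between them can be read: the limit of < 10% in this assay, at which 4 of the 4 values shown sit.

The compounds shown leave open whether methoxy to hydroxy changes the maximal response at all.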